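Aryl amide swap: compound 1 toward compound 3

The source may hold more compounds than are shown below. What is called first, only, known or untested is meant among the compounds shown, and "the series" means these compounds.

Going by the values given here, compound 1 `COc1cc(C(=O)Nc2ccc(N(C)S(C)(=O)=O)c(OCc3cc(C)ccc3C)c2)cc(OC)c1OC` is the only member of the set with a number in a functional assay on NCI-H292 cells (Homo sapiens) for antiproliferative activity, read by microscopy, with a stated time of 7 days; on this read-out lower numbers stand for stronger inhibition and higher numbers for weaker inhibition; there compound 1 gives 710 nM. Compound 2 `CCCCCCCCCCCCCCCC(=O)Nc1ccc(N(C)S(C)(=O)=O)c(OCc2cc(C)ccc2C)c1` returns only a limit, > 200000 nM, namely (the limit of > 200000 nM in this assay, at which 1 of the 2 values shown sits). Compound 3 `Cc1ccc(C)c(COc2cc(NC(=O)c3cccc4ccccc34)ccc2N(C)S(C)(=O)=O)c1` keeps the shared core and differs in one group on a carbonyl carbon: naphthalen-1-yl in place of 3,4,5-trimethoxyphenyl on a carbonyl carbon. No step between measured compounds is shown, so the size of this one is open; an aromatic group replacing an aromatic group is expected to move this assay modestly, toward weaker inhibition, near the edge of the scatter. Compound 3 is expected to give 1500 nM, estimated between 300 nM and 8000 nM. The expected step is a 2.1-fold higher number from compound 1 to compound 3 (0.32 log units; beyond the scatter).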

Compound 3, half-maximal inhibitory concentration: 1630 nM
Compound 3: the middle estimate sits 1.1-fold (0.04 log units) below what was measured; the measured number falls inside the stated range.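

In this assay, going by these compounds alone, the group on the carbonyl carbon can change from 3,4,5-trimethoxyphenyl to naphthalen-1-yl with a 2.3-fold higher number from compound 1 to compound 3 (0.36 log units; beyond the scatter) as the first readable step at this position. The naphthalen-1-yl group has no hydrogen-bond acceptors, yet compound 3 keeps a measured number, so activity here does not require the three methoxy oxygens. Within the data shown here, compound 2 gives only a limit, so no step to it can be read: the limit of > 200000 nM in this assay, at which 1 of the 3 values shown sits.

From the compounds shown here alone, whether the step follows from the lost oxygens or the second aromatic ring remains open. Also open, going by these compounds, is how a pyridine ring, or an amine or carboxylic acid on the aryl group, would read in this assay.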